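The source may report more compounds than this note shows. Statements on the series, on what has been measured and on what is new or still open speak of the compounds shown alone.

In a functional assay on Jurkat cells (Homo sapiens) for antiproliferative activity, read by MTT assay, with a stated time of 48 h (on this read-out higher numbers stand for weaker inhibition and lower numbers for stronger inhibition), compound 2 `O=C(CCCCCCn1cc(Nc2ncc(Cl)c(Nc3cccc(Cl)c3)n2)cn1)NO` gives 100 nM, which lies within the scatter of compound 1 `O=C(/C=C/c1ccc(Cn2cc(Nc3ncc(Cl)c(Nc4ccc(F)cc4)n3)cn2)cc1)NO` at 150 nM and of compound 3 `O=C(CCCCCn1cc(Nc2ncc(Cl)c(Nc3cccc(Cl)c3)n2)cn1)NO` at 50 nM. Compound 4 `CNc1nc(Nc2cnn(CCCCCCC(=O)NO)c2)ncc1Cl` keeps the chain of compound 2 and differs elsewhere: methyl in place of 3-chlorophenyl on a nitrogen on an aromatic ring. Within the data shown here, the only measured step, a 2.0-fold lower number from compound 2 to compound 3 (0.30 log units; within the scatter), concerns the chain and does not touch this group. All three measured compounds keep a substituted phenyl on that nitrogen, so the data offer no direct guide to its removal. Weaker inhibition beyond the scatter is tentatively expected, as an estimated 5.0-fold higher number from compound 2 to compound 4 (0.70 log units; beyond the scatter). Compound 4 is estimated at 500 nM, with an expected range of 120 nM to 2500 nM.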

Compound 4, half-maximal inhibitory concentration: 70 nM
Beside the measured number, compound 4's estimate is 7.1-fold (0.85 log units) above it; the whole stated range lies above it.
By their numbers in this assay, from the lowest: compounds 3, 4, 2 and 1 (each within the scatter of the next, the first and the last beyond it).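

In this assay, methyl in place of 3-chlorophenyl on a nitrogen on an aromatic ring gives a 1.4-fold lower number from compound 2 to compound 4 (0.15 log units; within the scatter). The earlier compounds shown here all carried a substituted phenyl there; this step shows that, on the chain of compound 2, the aromatic ring at this position can go without the number leaving the scatter. No available evidence accounts for this result. As far as these compounds go, whether hydrogen or a longer group such as butyl or benzyl on that nitrogen would behave like methyl stays open. So does whether methyl gives the same outcome on the shorter chain of compound 3.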